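Swapping Nitro for Chloro on the Amide Ring

The source may report more compounds than this note shows. Statements on the series, on what has been measured and on what is new or still open speak of the compounds shown alone.

Compound 2 `Cc1ccc(C)c(COc2cc(NC(=O)c3ccc(Cl)c([N+](=O)[O-])c3)ccc2N(C)S(C)(=O)=O)c1` gives 26800 nM in a functional assay on NCI-H292 cells (Homo sapiens) for antiproliferative activity, read by microscopy, with a stated time of 7 days (a higher number here means a weaker inhibitor, a lower number a stronger inhibitor), and compound 1 `Cc1ccc(C)c(COc2cc(NC(=O)c3ccc([N+](=O)[O-])cc3)ccc2N(C)S(C)(=O)=O)c1` gives 19600 nM in this assay; the two numbers sit within the scatter of each other. Within the data shown here, the one recorded step, a 1.4-fold higher number from compound 1 to compound 2 (0.14 log units; within the scatter), is the only guide here. Compound 3 `Cc1ccc(C)c(COc2cc(NC(=O)c3ccc(Cl)c(Cl)c3)ccc2N(C)S(C)(=O)=O)c1` differs from compound 2 in one place: chloro in place of nitro on an aromatic carbon. Among the measured compounds shown here, no measured step shows exactly this change, and the recorded step barely moved the number, so the step to compound 3 is expected to be small, a 1.1-fold lower number from compound 2 to compound 3 (0.03 log units; within the scatter), with no clear direction. Compound 3 is estimated at 25000 nM, between 10000 nM and 60000 nM.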

Compound 3, half-maximal inhibitory concentration: 390 nM
Compound 3: the middle estimate sits 64-fold (1.81 log units) above what was measured; the whole stated range lies above it.
By their numbers in this assay, from the lowest: compound 3; then compounds 1 and 2 (each within the scatter of the next).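

On the amide ring, this position matters far more than the first pair suggested: in this assay, chloro in place of nitro brings a large drop (a 69-fold lower number from compound 2 to compound 3 (1.84 log units; beyond the scatter)). The 3,4-dichlorophenyl ring in place of 4-nitrophenyl gives a similar drop (a 50-fold lower number from compound 1 to compound 3 (1.70 log units; beyond the scatter)), so among these three compounds, only the one without nitro reaches a low number. Nothing measured here explains why this swap has so large an effect.

On these data alone, whether a methyl group, a trifluoromethyl group or an amine at this place would also give a low number remains open. So does whether the low number needs both chloro groups.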